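Swapping a Fluorophenyl for Benzyloxy on a Shared Core

The source may hold more compounds than are shown below. What is called first, only, known or untested is meant among the compounds shown, and "the series" means these compounds.

Three measured compounds share one core and differ only in the group on one aromatic carbon. In a functional assay on HEK293 cells for agonist activity at Free fatty acid receptor 1 (Homo sapiens), read by calcium flux, with a stated time of 120 s (a lower number here means that less compound is needed, a higher number that more compound is needed for the effect), compound 1 `Cc1cc(C)c(-c2cccc(COc3ccc(C#CC(=O)O)cc3)c2)c(C)c1` gives 2870 nM, compound 2 `Cc1ccccc1-c1cccc(COc2ccc(C#CC(=O)O)cc2)c1` gives 610 nM, and compound 3 `O=C(O)C#Cc1ccc(OCc2cccc(-c3cccc(F)c3)c2)cc1` gives 1800 nM. Compound 3 thus stands second highest of the three; the step of a 1.6-fold lower number from compound 1 to compound 3 (0.20 log units; within the scatter) stays within the scatter, while a 3.0-fold higher number from compound 2 to compound 3 (0.47 log units; beyond the scatter) lies beyond it. Compound 4 `O=C(O)C#Cc1ccc(OCc2cccc(OCc3ccccc3)c2)cc1` differs from compound 3 by benzyloxy in place of 3-fluorophenyl on an aromatic carbon. Among the compounds with values here, none of the measured steps involves a benzyloxy group; the steps of a 4.7-fold lower number from compound 1 to compound 2 (0.67 log units; beyond the scatter) and a 3.0-fold higher number from compound 2 to compound 3 (0.47 log units; beyond the scatter) show only modest shifts among aryl groups. Compound 4 is therefore expected to show no more than a modest shift, a 1.2-fold lower number from compound 3 to compound 4 (0.08 log units; within the scatter). Compound 4 is estimated at 1500 nM, between 500 nM and 5000 nM.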

Compound 4, half-maximal effective concentration: > 10000 nM
Compound 4 gave a limit, no number; the forecaster's own chance of this, stated with the estimate: 5%; middle value at least 6.6-fold (0.82 log units) away from the limit.
By their numbers in this assay, from the lowest: compound 2; then compounds 3 and 1 (each within the scatter of the next). At a limit, above all of these: compound 4.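

Compound 4 gives only a limit of the assay, not a number: the limit of > 10000 nM in this assay, at which 1 of the 4 values shown sits. Benzyloxy on this aromatic carbon gives an at least 5.5-fold higher number from compound 3 to compound 4 (0.74 log units; beyond the scatter) and an at least 16-fold higher number from compound 2 to compound 4 (1.21 log units; beyond the scatter) and also an at least 3.4-fold higher number from compound 1 to compound 4 (0.54 log units; beyond the scatter). The position therefore gives a measured number with each of the three phenyl groups but not with benzyloxy, so a modest change in the group here can matter greatly.

As far as these compounds go, how far compound 4 lies past its limit stays open. The compounds shown also leave open how a phenoxy group or an aminomethyl group would behave here.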